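Sulfonamide amines against pancreatic cell growth: a methoxy replaces phenyl

A few compounds are considered here, and "the series" means these few. Any claim that something is new, unique, unknown or untested is made for them only; others in the source may bear on it.

Measured so far:
Compound 1 `O=S(=O)(NCCCNCC1COc2ccccc2O1)c1cc(C(F)(F)F)cc(C(F)(F)F)c1` gives 3400 nM in a functional assay on PANC-1 cells (Homo sapiens) for inhibition, read by MTT assay, with a stated time of 72 h; a higher number here means a weaker inhibitor of growth, a lower number a stronger inhibitor of growth.
Compound 2 `O=S(=O)(NCCCNCc1ccccc1)c1cc(C(F)(F)F)cc(C(F)(F)F)c1` gives 16000 nM in this assay.
Compound 3 `O=S(=O)(NCCCNCc1ccc(-c2ccccc2)cc1)c1cc(C(F)(F)F)cc(C(F)(F)F)c1` gives 2500 nM in this assay.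

Compound 3 holds the lowest of the three numbers in this assay, though its gap to compound 1 lies within the scatter; only its gap to compound 2 is beyond it. Compound 4 `COc1ccc(CNCCCNS(=O)(=O)c2cc(C(F)(F)F)cc(C(F)(F)F)c2)cc1` differs from compound 3 by methoxy in place of phenyl on an aromatic carbon, on an aromatic carbon of a six-membered aromatic ring of carbon only, para to a large group. The step that bears on this change is a 6.4-fold lower number from compound 2 to compound 3 (0.81 log units; beyond the scatter), which shows how much the phenyl on that ring gained over hydrogen. Compound 4 keeps neither hydrogen nor phenyl there but a methoxy, a far smaller group, so the number is expected to move back part of the way toward compound 2 but not all of it; the expected step is a 3.2-fold higher number from compound 3 to compound 4 (0.51 log units; beyond the scatter). For compound 4 the estimate in this assay is therefore 8000 nM, within 3000 nM to 20000 nM.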

Compound 4, concentration for 50% growth inhibition: 11000 nM
Compound 4: middle estimate off by 1.4-fold (0.14 log units), on the low side; measured number inside the range.
By their numbers in this assay, from the lowest: compounds 3 and 1 (each within the scatter of the next); then compounds 4 and 2 (each within the scatter of the next).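

In this assay, the gain seen with the phenyl on this aromatic carbon does not carry over to a methoxy: replacing that phenyl gives a 4.4-fold higher number from compound 3 to compound 4 (0.64 log units; beyond the scatter) and the comparison with hydrogen at the same place gives a 1.5-fold lower number from compound 2 to compound 4 (0.16 log units; within the scatter) which lies within the scatter, so compound 4 cannot be told apart from compound 2. The 4-methoxyphenyl group also falls short of the 2,3-dihydro-1,4-benzodioxin-2-yl group, with a 3.2-fold higher number from compound 1 to compound 4 (0.51 log units; beyond the scatter) as the step between them. No measurement at hand accounts for these differences.

Among the compounds shown, only phenyl at this carbon stands apart from hydrogen, so it remains open whether another ring, such as a cyclohexyl or a pyridine ring, would do the same. From the compounds shown here alone, it also remains open whether a longer chain between the two nitrogens would change the size of these steps.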